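Chloro substitution on two purine-like cores against PC-3 growth

The compounds below may be only part of what the source reports. "The series", "measured", "known", "first", "only" and "open" are said of these compounds alone.

Measured compounds:
compound 1 `ClCc1ccccc1Cn1cnc2c(Cl)nc(Cl)nc21`, 440 nM
compound 2 `ClCc1ccccc1Cn1cnc2c(Cl)ncnc21`, 3020 nM
compound 3 `ClCc1ccccc1Cn1cnc2ncnc(Cl)c21`, 4460 nM

In a functional assay on PC-3 cells (Homo sapiens) for cytotoxicity, read by sulforhodamine B assay, with a stated time of 48 h (a higher number here means a weaker inhibitor of growth, a lower number a stronger inhibitor of growth), compound 2 and compound 1 share a core and differ only by chloro in place of hydrogen on an aromatic carbon, a step of a 6.9-fold lower number from compound 2 to compound 1 (0.84 log units; beyond the scatter). Compound 3 has the same atoms as compound 2 joined differently; the difference between the two cores is not broken down here. Compound 4 `ClCc1ccccc1Cn1cnc2nc(Cl)nc(Cl)c21` is not yet measured. It differs from compound 3 by chloro in place of hydrogen on an aromatic carbon, the same change as from compound 2 to compound 1. Within the data shown here, the step from compound 3 to compound 4 is expected to be a 5.6-fold lower number from compound 3 to compound 4 (0.75 log units; beyond the scatter), resting on the one earlier step, although the core differs, so a smaller effect is held open. Compound 4 is thus estimated at 800 nM in this assay.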

Compound 4, concentration for 50% growth inhibition: 750 nM
Compound 4: middle estimate off by 1.1-fold (0.03 log units), on the high side, and the stated range covers the measured number.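

In this assay the chloro in place of hydrogen on an aromatic carbon gives a 5.9-fold lower number from compound 3 to compound 4 (0.77 log units; beyond the scatter) and so matches the step seen on the other core: the same change on two cores in this assay, a 6.9-fold lower number (0.84 log units; beyond the scatter) from compound 2 to compound 1 and a 5.9-fold lower number (0.77 log units; beyond the scatter) from compound 3 to compound 4, 1.2-fold (0.06 log units) apart, within the scatter of two such steps. Across these two pairs, then, the change carries from one core to the other with much the same size. Among these compounds, this rests on only two pairs in a single cell assay, so it does not show that the step would hold on a further core or in another assay, nor does it explain why the number falls.

The compounds shown leave open whether an amine or a methoxy group on that same carbon, between two ring nitrogen atoms, would carry across the two cores in the same way. They also leave open how either core would respond if a longer chain took the place of that chloro.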